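The source may hold more compounds than are shown below. What is called first, only, known or untested is meant among the compounds shown, and "the series" means these compounds.

Compound 2 `O=C(CCCCCCn1cc(-c2cccnc2)nn1)Nc1ccccc1Cc1ccccc1` was tested in a functional assay on SH-SY5Y cells (Homo sapiens) for cytotoxicity, tested at 300 nM (a lower number here means a stronger effect, a higher number a weaker effect of the compound at the concentration tested), and gave 86.1%. Among the three compounds measured, compound 2 stands highest, meaning the weakest effect. Compound 3 `O=C(CCCCCCCn1cc(-c2cccnc2)nn1)Nc1ccccc1Cc1ccccc1` gave 75.2%, and compound 1 `O=C(CCCCCCCCn1cc(-c2cccnc2)nn1)Nc1ccccc1-c1ccccc1` gave 35.6%, both beyond the scatter below compound 2. Compound 4 `O=C(CCCCCCn1cc(-c2cccnc2)nn1)Nc1ccccc1Cl` has not yet been measured; it differs from compound 2 by chloro in place of benzyl on an aromatic carbon. For the measured compounds named here, no pair among the measured compounds shares this change, so nothing measured shows its effect. The expectation is therefore cautious: the step from compound 2 to compound 4 is expected to stay within the scatter a number 4.1 percentage points lower from compound 2 to compound 4 (within the scatter). Compound 4 is expected to give about 82%, with a range from 60% to 100%.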

Compound 4, a percentage reported as activity, at one concentration (the size of the read-out at that concentration, not a potency): 79.5%
The estimate for compound 4 lay 2.5 percentage points above the measured number, and the stated range covers the measured number.
By their numbers in this assay, from the lowest: compound 1; then compounds 3, 4 and 2 (each within the scatter of the next, the first and the last beyond it).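

In this assay, putting chloro in place of benzyl on this aromatic carbon, ortho to a large group, gives a number 6.6 percentage points lower from compound 2 to compound 4 (within the scatter). A group carrying a six-membered aromatic ring can therefore give way to a single chlorine atom here with no shift beyond the scatter. Nothing available explains this outcome. As far as these compounds go, whether an amine or a carboxylic acid on this aromatic carbon would also stay within the scatter remains open. So does whether chloro would behave the same way on a longer chain.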